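This account rests on a few compounds, and the source may have more. Where it says the series, first, only, none or still open, it means among the compounds named here.

Measured in a functional assay on MCF7 cells (Homo sapiens) for antiproliferative activity, read by MTT assay, with a stated time of 24 h; a lower number here means a stronger inhibitor, a higher number a weaker inhibitor:
Compound 1 `CCn1c(C(=O)NCCO)ccc1C(CC)(CC)c1ccc(OCS(=O)(=O)c2ccccc2)c(C)c1`: 15500 nM
Compound 2 `CCn1c(C(=O)N[C@H](C)C(=O)O)ccc1C(CC)(CC)c1ccc(OCS(=O)(=O)c2ccccc2)c(C)c1`: > 50000 nM, a limit of the assay and not a number
Compound 3 `CCn1c(C(=O)N[C@H](C(=O)O)C(C)C)ccc1C(CC)(CC)c1ccc(OCS(=O)(=O)c2ccccc2)c(C)c1`: 24500 nM

Going by the values given here, compound 3 lies within the scatter of compound 1, the only other compound with an actual number. Compound 4 `CCn1c(C(=O)N[C@H](CC(=O)O)C(=O)O)ccc1C(CC)(CC)c1ccc(OCS(=O)(=O)c2ccccc2)c(C)c1` carries 1,2-dicarboxyethyl in place of 1-carboxy-2-methylpropyl on an amide-type nitrogen.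

The closest measured change swaps 1-carboxyethyl for 1-carboxy-2-methylpropyl, and it gives an at least 2.0-fold lower number from compound 2 to compound 3 (0.30 log units; that floor lies within the scatter), a floor that lies within the scatter. The step of an at least 3.2-fold higher number from compound 1 to compound 2 (0.50 log units; beyond the scatter) goes beyond the scatter, while a 1.6-fold higher number from compound 1 to compound 3 (0.20 log units; within the scatter) stays within it. Since the entering group shares its name stem with 1-carboxyethyl, and because an at least 2.0-fold lower number from compound 2 to compound 3 (0.30 log units; that floor lies within the scatter) points towards a higher number on leaving 1-carboxy-2-methylpropyl, a modest rise in this assay is expected, and the assay limit may well be reached. The expected step is a 1.6-fold higher number from compound 3 to compound 4 (0.21 log units; within the scatter). For compound 4 the estimated value is 40000 nM, with an expected range of 18000 nM to 90000 nM.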

Compound 4, half-maximal inhibitory concentration: > 50000 nM
Compound 4 ended at the assay's limit; the forecaster's own chance of this, stated with the estimate: 45%; middle value at least 1.2-fold (0.09 log units) away from the limit.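

In this assay the change to 1,2-dicarboxyethyl on the amide-type nitrogen gives an at least 2.0-fold higher number from compound 3 to compound 4 (0.30 log units; that floor lies within the scatter) and so, on its floor alone, is not separated from 1-carboxy-2-methylpropyl. Set against 2-hydroxyethyl, the same group gives an at least 3.2-fold higher number from compound 1 to compound 4 (0.50 log units; beyond the scatter) and joins 1-carboxyethyl in compound 2 beyond the scatter of compound 1, while compound 3 goes against this pattern by staying within that scatter. The step from compound 2 to compound 4, an added carboxy on the saturated chain carbon, cannot be read: the limit of > 50000 nM in this assay, at which 2 of the 4 values shown sit.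

On these data alone, how far the second carboxylic acid of compound 4 moves the activity therefore stays open. Also open, as far as these compounds go, is whether an amine or a longer chain ending in a hydroxyl on this nitrogen would give a number lower than that of compound 1.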